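This account rests on a few compounds, and the source may have more. Where it says the series, first, only, none or still open, it means among the compounds named here.

Measured in a functional assay on THP-1 cells (Homo sapiens) for inhibition, read by sulforhodamine B assay, with a stated time of 48 h, tested at 50 uM; on this read-out lower numbers stand for less inhibition of growth and higher numbers for more inhibition of growth at the one concentration tested:
- compound 1 `COc1cc(/C=C/C(=O)/C=C/c2ccco2)ccc1OCc1cn(CCCOc2cc(=O)oc3ccccc23)nn1`: 57%
- compound 2 `COc1ccc(/C=C/C(=O)/C=C/c2ccc(OCc3cn(CCCOc4cc(=O)oc5ccccc45)nn3)c(OC)c2)cc1`: 56%

Compound 2, at 56%, stands level, within the scatter, with compound 1 at 57%. Compound 3 `COc1cc(/C=C/C(=O)/C=C/c2cc(OC)c(OC)c(OC)c2)ccc1OCc1cn(CCCOc2cc(=O)oc3ccccc23)nn1` differs from compound 2 as follows: 3,4,5-trimethoxyphenyl in place of 4-methoxyphenyl on a double-bonded chain carbon bound to a double-bonded chain carbon. Among the compounds with values here, the only measured step at this place on the chain, a number 1 percentage points lower from compound 1 to compound 2 (within the scatter), lies within the scatter, and it swaps a different pair of groups. Nothing measured therefore points to a real shift in this assay, and no change beyond the scatter is expected. The expected step is a number 1 percentage points higher from compound 2 to compound 3 (within the scatter). The estimated value for compound 3 is 57%, within an expected range of 45% to 69%.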

Compound 3, percent growth inhibition at one concentration: 79%
Compound 3: middle estimate off by 22 percentage points, on the low side, and the stated range ends below it.
By their numbers in this assay, from the lowest: compounds 2 and 1 (each within the scatter of the next); then compound 3.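

In this assay, the group on a double-bonded chain carbon bound to a double-bonded chain carbon can move the read-out beyond the scatter: 3,4,5-trimethoxyphenyl gives a clear rise (a number 23 percentage points higher from compound 2 to compound 3 (beyond the scatter)) and (a number 22 percentage points higher from compound 1 to compound 3 (beyond the scatter)), whereas the earlier swap of furan-2-yl for 4-methoxyphenyl did not. So a single methoxy group on the phenyl ring does not carry this rise, and nothing at hand explains it. Still open, going by these compounds, is whether all three methoxy groups are needed, as a 3,4-dimethoxyphenyl would show, and how an amine such as 4-dimethylaminophenyl would read at this place.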